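The compounds below may be only part of what the source reports. "The series", "measured", "known", "first", "only" and "open" are said of these compounds alone.

Compound 3 `COCCOc1ccc(NC(=O)N(O)C2N(c3ccc(Cl)cc3)C(=O)N(CC(=O)N/N=C/C=C/c3ccc(C)o3)C2(C)C)cc1` stands second highest of the three numbers measured in a functional assay on MIA PaCa-2 cells (Homo sapiens) for antiproliferative activity, read by MTT assay, with a stated time of 72 h; a lower number here means that less compound is needed, a higher number that more compound is needed for the effect; in that assay compound 3 gives 5400 nM. Compound 1 `COCCOc1ccc(N2C(=O)N(CC(=O)N/N=C/C=C/c3ccc(C)o3)C(C)(C)C2N(O)C(=O)Nc2ccc(Cl)cc2)cc1` gives 6300 nM, and compound 2 `Cc1ccc(/C=C/C=N/NC(=O)CN2C(=O)N(c3ccc(Cl)cc3)C(N(O)C(=O)Nc3ccc(Cl)cc3)C2(C)C)o1` gives 4100 nM, so all three numbers sit close together. Compound 4 `COCCOc1ccc(NC(=O)N(O)C2N(c3ccc(OCCOC)cc3)C(=O)N(CC(=O)N/N=C/C=C/c3ccc(C)o3)C2(C)C)cc1` differs from compound 3 by 2-methoxyethoxy in place of chloro on an aromatic carbon. The same kind of swap has been seen twice among the measured compounds, in a 1.5-fold lower number from compound 1 to compound 2 (0.19 log units; within the scatter) and in a 1.3-fold higher number from compound 2 to compound 3 (0.12 log units; within the scatter), and both of those steps fell within the scatter. The step from compound 3 to compound 4 is therefore expected to stay within the scatter too, with no clear direction. Compound 4 is expected to give 6500 nM, with a range from 3500 nM to 12000 nM. The estimated step is a 1.2-fold higher number from compound 3 to compound 4 (0.08 log units; within the scatter).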

Compound 4, half-maximal effective concentration: 38400 nM
Estimate against measurement, compound 4: 5.9-fold (0.77 log units) below, and the stated range ends below it.
By their numbers in this assay, from the lowest: compounds 2, 3 and 1 (each within the scatter of the next); then compound 4.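

The swap of chloro for 2-methoxyethoxy on an aromatic carbon, which stayed within the scatter while a chloro remained in both partners, gives a 7.1-fold higher number from compound 3 to compound 4 (0.85 log units; beyond the scatter) and a 6.1-fold higher number from compound 1 to compound 4 (0.78 log units; beyond the scatter) in this assay once no chloro is left. The size of this change therefore depends on the core that carries it: the same change on two cores in this assay, a 1.5-fold lower number (0.19 log units; within the scatter) from compound 1 to compound 2 and a 7.1-fold lower number (0.85 log units; beyond the scatter) from compound 4 to compound 3, 4.6-fold (0.67 log units) apart, beyond the scatter of two such steps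

The second pair of steps reads the same way: the same change on two cores in this assay, a 1.3-fold higher number (0.12 log units; within the scatter) from compound 2 to compound 3 and a 6.1-fold higher number (0.78 log units; beyond the scatter) from compound 1 to compound 4, 4.6-fold (0.67 log units) apart, beyond the scatter of two such steps

Going by these compounds, what a methoxy or an amine would do at this position stays open. On these data alone, it also stays open whether the higher number follows from losing the last chloro or from carrying 2-methoxyethoxy on both aromatic rings.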